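Piperidine for Pyrrolidine on the Thiocarbonyl Carbon

The source may report more compounds than this note shows. Statements on the series, on what has been measured and on what is new or still open speak of the compounds shown alone.

Compound 2 `Cc1ccnc(/C(N)=N/NC(=S)N2CCCC2)c1` gives 1200 nM in a functional assay on MCF7 cells (Homo sapiens) for cytotoxicity, read by MTT assay, with a stated time of 72 h (on this read-out higher numbers stand for weaker inhibition and lower numbers for stronger inhibition), the lowest of the three numbers shown. Compound 1 `Cc1ccnc(/C(N)=N/NC(=S)N2CCSCC2)c1` gives 6900 nM in this assay, and compound 3 `N/C(=N\NC(=S)N1CCN(c2ccccn2)CC1)c1ccc(F)cn1` gives 22000 nM. Compound 4 `Cc1ccnc(/C(N)=N/NC(=S)N2CCCCC2)c1` has not been measured; it differs from compound 2 in one place: piperidin-1-yl in place of pyrrolidin-1-yl on a thiocarbonyl carbon. Among the compounds with values here, the only measured step at this place is a 5.8-fold lower number from compound 1 to compound 2 (0.76 log units; beyond the scatter), in which thiomorpholin-4-yl gave way to pyrrolidin-1-yl. Compound 4 returns to a six-membered ring but not to thiomorpholin-4-yl, so any move back toward a higher number is expected to be smaller than that step, and may stay within the scatter. Compound 4 is therefore expected to give 2500 nM, within 900 nM to 7000 nM, which is estimated as a 2.1-fold higher number from compound 2 to compound 4 (0.32 log units; beyond the scatter).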

Compound 4, half-maximal inhibitory concentration: 18800 nM
Beside the measured number, compound 4's estimate is 7.5-fold (0.88 log units) below it; the measured number lies above the stated range.
By their numbers in this assay, from the lowest: compound 2; then compound 1; then compounds 4 and 3 (each within the scatter of the next).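

In this assay, within the data shown here, the thiocarbonyl substituent proves far more sensitive than the earlier compounds showed: there is a 16-fold higher number from compound 2 to compound 4 (1.19 log units; beyond the scatter) when piperidin-1-yl replaces pyrrolidin-1-yl. The two six-membered rings also differ, with a 2.7-fold higher number from compound 1 to compound 4 (0.44 log units; beyond the scatter), so the lower number of compound 2 cannot be traced to replacing thiomorpholin-4-yl alone. Nothing available here explains either step. Still open, as far as these compounds go, is where morpholin-4-yl, azepan-1-yl or an open-chain dimethylamino group would fall relative to these rings, and whether pyrrolidin-1-yl would keep its lower number on a different core.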